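A few compounds are considered here, and "the series" means these few. Any claim that something is new, unique, unknown or untested is made for them only; others in the source may bear on it.

Measured so far:
compound 1, `CS(=O)(=O)c1ccc(C(=O)Nc2ccc(Cl)c(-c3nnc4c(Cl)cccn34)c2)c(Cl)c1`: 44600 nM
compound 2, `O=C(Nc1ccc(Cl)c(-c2nnc3c(Cl)cccn23)c1)c1c(F)cccc1Cl`: > 100000 nM

Two amides on a shared core have been tested in a functional assay on U-251 cells (Homo sapiens) for antiproliferative activity, read by MTT assay, with a stated time of 72 h; on this read-out lower numbers stand for stronger inhibition and higher numbers for weaker inhibition. Compound 1 gives 44600 nM in this assay, a weak effect. For compound 2 the result is only a limit, > 100000 nM, and not a number. This is the limit of > 100000 nM in this assay, at which 1 of the 2 values shown sits. Compound 2 therefore stands at the weak end of the two results, and no finer position can be given for it.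

Compound 3, `CS(=O)(=O)c1cccc(C(=O)Nc2ccc(Cl)c(-c3nnc4c(Cl)cccn34)c2)c1`, has not yet been measured. It differs from compound 2 in one place: 3-(methylsulfonyl)phenyl in place of 2-chloro-6-fluorophenyl on a carbonyl carbon. For the measured compounds named here, no step between the two measured compounds is recorded, so the expectation rests on the two values alone. It leans on compound 1, the other measured compound, which gives 44600 nM in this assay. The expected step is an at least 1.6-fold lower number from compound 2 to compound 3 (0.22 log units; that floor lies within the scatter), towards stronger inhibition but not beyond the weak range seen so far. Compound 3 is expected to give about 60000 nM in this assay, within a range from 20000 nM to 150000 nM, with a real chance that only a limit is reported again.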

Compound 3, half-maximal inhibitory concentration: > 100000 nM
Compound 3 ended at the assay's limit; the forecaster's own chance of this, stated with the estimate: 40%; middle value at least 1.6-fold (0.22 log units) away from the limit.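

Compound 2 and compound 3 both end as limits and not as numbers in this assay and so no step can be read between them, since each sits at the same limit: the limit of > 100000 nM in this assay, at which 2 of the 3 values shown sit.

The compounds shown leave open whether 3-(methylsulfonyl)phenyl and 2-chloro-6-fluorophenyl on the carbonyl carbon differ at all in this assay.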